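The source may report more compounds than this note shows. Statements on the series, on what has been measured and on what is new or still open speak of the compounds shown alone.

Measured so far:
- compound 1, `Cc1ccccc1-n1nc(-c2ccccc2)nc1CNc1ccc(C(=O)NO)cc1`, 57.1%
- compound 2, `O=C(NO)c1ccc(NCc2nc(-c3cccnc3)nn2-c2ccccc2)cc1`, 57.7%
- compound 3, `O=C(NO)c1ccc(NCc2nc(-c3ccc(Cl)cc3)nn2-c2ccccc2)cc1`, 67.2%

All three compounds were tested in an assay on Sf9 cells for inhibition of protein deacetylase HDAC6 (Homo sapiens), read by fluorescence, with a stated time of 40 min, tested at 100 nM; on this read-out lower numbers stand for less inhibition and higher numbers for more inhibition at the one concentration tested (going by the name of the read-out). Compound 1 gives the lowest of the three numbers. Its nearest neighbour is compound 2, which lies within the scatter of it, so the two cannot be told apart; compound 3 sits beyond the scatter above compound 1.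

Compound 4, `O=C(NO)c1ccc(NCc2nc(-c3ccccc3)nn2-c2ccc(Br)cc2)cc1`, has not yet been measured. It differs from compound 1 in one place: 4-bromophenyl in place of 2-methylphenyl on an aromatic nitrogen.

Within the data shown here, only one single-place step is known among the measured compounds, a number 9.5 percentage points higher from compound 2 to compound 3 (within the scatter), and it concerns the aryl group on an aromatic carbon rather than the group on the aromatic nitrogen. Among the measured compounds shown here, no measured step touches the position changed here, so nothing in the data points to a direction. The known step was small, and swapping one aromatic ring for another of the same size elsewhere in the core did not move the number beyond the scatter. A change of similar size is therefore expected here, a number 3.9 percentage points higher from compound 1 to compound 4 (within the scatter), most likely within the scatter.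

Compound 4 is thus estimated at 61%, with a range from 45% to 77%.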

Compound 4, a percentage reported as inhibition, at one concentration (the size of the read-out at that concentration, not a potency): 65.9%
Compound 4: the middle estimate sits 4.9 percentage points below what was measured; low and high end bracket the measured number.
By their numbers in this assay, from the lowest: compounds 1, 2, 4 and 3 (each within the scatter of the next, the first and the last beyond it).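

In this assay, the group on the aromatic nitrogen now has a step of its own, the first at this position: a number 8.8 percentage points higher from compound 1 to compound 4 (within the scatter). So 4-bromophenyl can take the place of 2-methylphenyl with no change that can be told apart from the usual scatter, even though the two groups differ in both the substituent they carry and where it sits on the phenyl ring. Nothing at hand explains the size of this step or separates the contribution of these two differences.

The compounds shown leave open whether the substituent or its place on the ring matters more, a question that 4-methylphenyl or 2-bromophenyl on the aromatic nitrogen could help to answer, since each would change only one of the two. They also leave open whether this position would respond more clearly to something other than a substituted phenyl ring, such as a butyl chain on the nitrogen or a phenyl ring bearing a carboxylic acid or an amine.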